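The source may hold more compounds than are shown below. What is called first, only, known or untested is meant among the compounds shown, and "the series" means these compounds.

Of the compounds shown here, three of one series have been measured in a functional assay on A549 cells (Homo sapiens) for antiproliferative activity, read by MTT assay, with a stated time of 48 h; on this read-out lower numbers stand for stronger inhibition and higher numbers for weaker inhibition. Compound 1 `Cc1cccc(-c2nn(-c3ccccc3)cc2C(Nc2nc3ccccc3s2)c2c(O)ccc3ccccc23)c1` gives 18500 nM in this assay. Compound 2 `Oc1ccc2ccccc2c1C(Nc1nc2ccccc2s1)c1cn(-c2ccccc2)nc1-c1cccc(Cl)c1` gives 20400 nM in this assay, and compound 3 `O=[N+]([O-])c1ccc(-c2nn(-c3ccccc3)cc2C(Nc2nc3ccc(Cl)cc3s2)c2c(O)ccc3ccccc23)cc1` gives 57200 nM in this assay, the highest number of the three, standing beyond the scatter from both of the others.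

Compounds 2 and 1 differ in one place: methyl in place of chloro on an aromatic carbon. The measured step of a 1.1-fold lower number from compound 2 to compound 1 (0.04 log units; within the scatter) shows that this exchange left the read-out essentially unchanged. How the core of compound 3 differs from the core of compound 2 is not broken down here.

Compound 4 `Cc1ccc2nc(NC(c3cn(-c4ccccc4)nc3-c3ccc([N+](=O)[O-])cc3)c3c(O)ccc4ccccc34)sc2c1` has not been measured. It differs from compound 3 by methyl in place of chloro on an aromatic carbon. Within the data shown here, this is the same kind of change as the one from compound 2 to compound 1, but not the same: in the earlier pair the place was on an aromatic carbon of a six-membered aromatic ring of carbon only, meta to a large group, whereas here the aromatic carbon belongs to a six-membered aromatic ring of carbon only that is part of a fused or bridged system of two rings, meta to a fused ring and para to a fused ring.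

On the strength of the step from compound 2 to compound 1, compound 4 is expected to move from compound 3 by about a 1.1-fold lower number from compound 3 to compound 4 (0.06 log units; within the scatter), a step within the scatter, because a 1.1-fold lower number from compound 2 to compound 1 (0.04 log units; within the scatter) was itself within the scatter. Compound 4 is therefore estimated at 50000 nM in this assay, most likely between 25000 nM and 100000 nM.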

Compound 4, half-maximal inhibitory concentration: 29000 nM
Compound 4: the middle estimate sits 1.7-fold (0.24 log units) above what was measured, and the stated range covers the measured number.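

In this assay, the new step reads a 2.0-fold lower number from compound 3 to compound 4 (0.29 log units; within the scatter), so exchanging 6-chloro-1,3-benzothiazol-2-yl for 6-methyl-1,3-benzothiazol-2-yl did not move the read-out beyond the scatter. Set beside the earlier exchange of chloro for methyl, the new step does not differ from it by more than the scatter allows: the same change on two cores in this assay, a 1.1-fold lower number (0.04 log units; within the scatter) from compound 2 to compound 1 and a 2.0-fold lower number (0.29 log units; within the scatter) from compound 3 to compound 4, 1.8-fold (0.25 log units) apart, within the scatter of two such steps This shows that, across these two pairs, the exchange carried from one core to the other without a measurable effect, even though the place in compound 4 lies on a ring that is part of a fused system and the earlier place does not; it does not show that the same would hold on other cores or at other places, and it gives no reason why the two cores agree.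

The compounds shown leave open what an amine, a carboxylic acid or a methoxy group would do at the place held by chloro or methyl. They also leave open whether the same exchange would stay as quiet on a core without the hydroxyl group, which every compound here carries.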